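A Chain Without the Amine: Expecting Compound 4

The source may report more compounds than this note shows. Statements on the series, on what has been measured and on what is new or still open speak of the compounds shown alone.

Three compounds have been measured in a functional assay on HeLa cells (Homo sapiens) for antiproliferative activity; on this read-out lower numbers stand for stronger inhibition and higher numbers for weaker inhibition:

compound 1, `COCCO/N=C/c1c(N)ncnc1Oc1ccc2[nH]c(C)cc2c1F`: 308 nM
compound 2, `COCCCO/N=C/c1c(N)ncnc1Oc1ccc2[nH]c(C)cc2c1F`: 346 nM
compound 3, `CNCCO/N=C/c1c(N)ncnc1Oc1ccc2[nH]c(C)cc2c1F`: 2010 nM

All three share the same core and differ only in a short side chain. Compound 3 stands highest of the three numbers, that is, it is the weakest inhibitor, and both of its measured steps lie beyond the scatter: a 6.5-fold higher number from compound 1 to compound 3 (0.81 log units; beyond the scatter) and a 5.8-fold higher number from compound 2 to compound 3 (0.76 log units; beyond the scatter). Among the measured compounds shown here, in each case the methylamino group is the only change, and in each case it brought a modest loss.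

Compound 4, `C=CCO/N=C/c1c(N)ncnc1Oc1ccc2[nH]c(C)cc2c1F`, has not yet been measured. Relative to compound 3 the change is vinyl in place of (methylamino)methyl on a saturated chain carbon bound to an oxygen on an unsaturated carbon. The group that set compound 3 apart from compounds 1 and 2 thus leaves, and a chain with no donor or acceptor takes its place. Since the two known steps bear directly on this, a reversal of similar size is expected: a 5.0-fold lower number from compound 3 to compound 4 (0.70 log units; beyond the scatter). Compound 4 is therefore expected to give 400 nM, with a range from 150 nM to 1000 nM.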

Compound 4, half-maximal inhibitory concentration: 42 nM
Compound 4: middle estimate off by 9.5-fold (0.98 log units), on the high side, outside the stated range (below it).
By their numbers in this assay, from the lowest: compound 4; then compounds 1 and 2 (each within the scatter of the next); then compound 3.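

Among the compounds shown here, the earlier compounds showed only that a change in this side chain could cost activity in this assay and that the 2-(methylamino)ethyl chain stood out as the poor one; the allyl chain shows that the same place can also give a large gain (a 48-fold lower number from compound 3 to compound 4 (1.68 log units; beyond the scatter)). Removing the amine is not the whole story, as the two chains that carry an ether oxygen and no amine also fall well short of allyl (an 8.2-fold lower number from compound 2 to compound 4 (0.92 log units; beyond the scatter); a 7.3-fold lower number from compound 1 to compound 4 (0.87 log units; beyond the scatter)). No measurement at hand explains these gaps.

On these data alone, whether the double bond itself matters stays open, and a saturated propyl chain in this place would separate that from simply having only carbon in the chain. A longer chain such as butenyl, or a cyclopropylmethyl group, would show whether the gain extends beyond allyl.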